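The source may hold more compounds than are shown below. What is called first, only, known or untested is meant among the compounds shown, and "the series" means these compounds.

Working notes on the series.

The shared core is carried unchanged by compound 1 `COc1cc(-c2nn(-c3cccc(NC(=O)Nc4cccc(C(F)(F)F)c4)c3)cc2-c2ccncc2)ccc1Cl` and compound 2 `COc1cc(-c2nn(-c3cccc(NC(=O)c4ccc(Cl)c(C(F)(F)F)c4)c3)cc2-c2ccncc2)ccc1Cl`. In a functional assay on IGROV-1 cells (Homo sapiens) for inhibition, read by sulforhodamine B assay, with a stated time of 48 h (on this read-out higher numbers stand for weaker inhibition of growth and lower numbers for stronger inhibition of growth), compound 1 gives 1060 nM, and in the same assay compound 2 gives 2150 nM. The one measured step, a 2.0-fold higher number from compound 1 to compound 2 (0.31 log units; beyond the scatter), swaps the urea-type linker of compound 1 for an amide and at the same time brings in the chlorine; on the two numbers shown compound 2 stands at the higher end, with compound 1 as its only neighbour.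

Compound 3 `COc1cc(-c2nn(-c3cccc(NC(=O)Nc4ccc(Cl)c(C(F)(F)F)c4)c3)cc2-c2ccncc2)ccc1Cl` differs from compound 2 by (4-chloro-3-(trifluoromethyl)phenyl)amino in place of 4-chloro-3-(trifluoromethyl)phenyl on a carbonyl carbon, which restores the urea-type linker of compound 1 while keeping the 4-chloro-3-(trifluoromethyl)phenyl group of compound 2. Among the compounds with values here, only the step from compound 1 to compound 2 bears on this, and it was modest; with the linker change undone, compound 3 is expected to move back toward the level of compound 1, by a 1.8-fold lower number from compound 2 to compound 3 (0.25 log units; within the scatter) in this assay. For compound 3 the estimate is 1200 nM, with a range from 500 nM to 3000 nM.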

Compound 3, concentration for 50% growth inhibition: 1200 nM
Estimate against measurement, compound 3: no gap at the digits printed; the measured number falls inside the stated range.
By their numbers in this assay, from the lowest: compounds 1, 3 and 2 (each within the scatter of the next, the first and the last beyond it).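

Two single changes now stand where the earlier pair offered only a combined one. With the 4-chloro-3-(trifluoromethyl)phenyl group held in place, the amino insertion on the carbonyl carbon, which gains the extra amide-type hydrogen-bond donor, gives a 1.8-fold lower number from compound 2 to compound 3 (0.25 log units; within the scatter) in this assay, while with the urea-type linker held, chloro on the aromatic carbon gives a 1.1-fold higher number from compound 1 to compound 3 (0.05 log units; within the scatter) on the same read-out. Each part therefore lies within the scatter although the combined step from the earlier pair, a 2.0-fold higher number from compound 1 to compound 2 (0.31 log units; beyond the scatter), lies beyond it, so neither change taken alone can be read as setting the gap, and no information on a cause is available for these steps.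

The compounds shown leave open how an amide carrying the 3-(trifluoromethyl)phenyl group without the chloro would read, which is the one compound that would complete this set of linker and chloro changes. They also leave open whether a fluoro, methyl or nitrile group in place of that chloro would separate from these three values by more than the scatter.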